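Halogen swap on the pendant ring: compound 2 to compound 4

The source may report more compounds than this note shows. Statements on the series, on what has been measured and on what is new or still open speak of the compounds shown alone.

Working notes on a small set of bicyclic cores carrying a halogenated aryl group. Compound 1 `O=c1oc2ccccc2c(=O)n1-c1ccc(Cl)cc1F` bears chloro and fluoro on the pendant ring and no halogen on the core; in an ADME assay on RAW264.7 cells (Mus musculus) for cytotoxicity, read by MTT assay, with a stated time of 24 h (on this read-out higher numbers stand for lower toxicity in this test and lower numbers for higher toxicity in this test), compound 1 gives 24400 nM. Compound 2 `O=c1oc2ccc(I)cc2c(=O)n1-c1ccc(Br)cc1F` carries iodo on the core and bromo on the pendant ring, and in this assay compound 2 gives 8300 nM. Compound 3 `O=c1oc2ccc(Cl)cc2c(=O)n1-c1ccc(Br)cc1F` replaces that iodo with chloro, and in this assay compound 3 gives 8100 nM. Among the three numbers compound 2 stands second highest: compound 3 is nearest, compound 1 furthest, with a gap beyond the scatter.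

Within the data shown here, the only single-change step known is a 1.0-fold lower number from compound 2 to compound 3 (0.01 log units; within the scatter), a halogen exchange on the core that moved nothing. Compound 4 `O=c1oc2ccc(I)cc2c(=O)n1-c1ccc(Cl)cc1F` is the next halogen exchange, this time on the pendant ring: chloro in place of bromo on an aromatic carbon. Among the measured compounds shown here, no measured step touches this exact position; compound 1 and compound 3 differ there, but also on the core, so their values cannot be split. Given the flat step from compound 2 to compound 3, a step of a 1.2-fold higher number from compound 2 to compound 4 (0.08 log units; within the scatter) within the scatter is expected from compound 2 to compound 4. Compound 4 is estimated at 10000 nM, between 5000 nM and 20000 nM.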

Compound 4, half-maximal cytotoxic concentration: 8900 nM
Beside the measured number, compound 4's estimate is 1.1-fold (0.05 log units) above it; the range from low to high includes it.
By their numbers in this assay, from the lowest: compounds 3, 2 and 4 (each within the scatter of the next); then compound 1.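

In this assay the exchange of chloro in place of bromo, on the aromatic carbon meta to a fluoro group and para to a large group, amounts to a 1.1-fold higher number from compound 2 to compound 4 (0.03 log units; within the scatter) and so stays within the scatter with iodo held on the core, which shows that this pendant position takes either halogen without a readable step. The same compound also gives the first single-change reading of a core halogen, iodo in place of hydrogen on an aromatic carbon, as a 2.7-fold lower number from compound 1 to compound 4 (0.44 log units; beyond the scatter) and thus a modest step beyond the scatter towards higher toxicity in this test, while both halogen-for-halogen exchanges, on the core and on the pendant ring, remain within it. (Nothing at hand accounts for either step)

The compounds shown leave open whether the pendant position stays as flat with a group other than a halogen, such as an amine, a methoxy group or a carboxylic acid. They also leave open whether such groups on the core would give a step like that of iodo in place of hydrogen.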